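Bromo for chloro: what compound 4 may show

This account rests on a few compounds, and the source may have more. Where it says the series, first, only, none or still open, it means among the compounds named here.

In a functional assay on A549 cells (Homo sapiens) for antiproliferative activity, read by MTT assay (on this read-out lower numbers stand for stronger inhibition and higher numbers for weaker inhibition), compound 1 (`Cn1c(=O)c(=O)n(C2CCCC2)c2nc(N/N=C/c3ccc(Cl)cc3)ncc21`) gives 6890 nM, compound 2 (`Cn1c(=O)c(=O)n(C2CCCC2)c2nc(N/N=C/c3ccc(C(F)(F)F)cc3)ncc21`) gives 40600 nM and compound 3 (`Cn1c(=O)c(=O)n(C2CCCC2)c2nc(N/N=C/c3ccc(F)cc3Cl)ncc21`) gives 11000 nM. Compound 3 lies within the scatter of compound 1, as a 1.6-fold higher number from compound 1 to compound 3 (0.20 log units; within the scatter) shows, and clearly under compound 2, with a 3.7-fold lower number from compound 2 to compound 3 (0.57 log units; beyond the scatter). Compound 4 (`Cn1c(=O)c(=O)n(C2CCCC2)c2nc(N/N=C/c3ccc(F)cc3Br)ncc21`) carries bromo in place of chloro on an aromatic carbon. Among the measured compounds shown here, no measured step makes this exchange. The nearest one replaces chloro with trifluoromethyl and stays modest, at a 5.9-fold higher number from compound 1 to compound 2 (0.77 log units; beyond the scatter). No change beyond the scatter is therefore expected in this assay. The estimated step is a 1.1-fold lower number from compound 3 to compound 4 (0.04 log units; within the scatter). Compound 4 is expected near 10000 nM, with an estimated range of 5000 nM to 21000 nM.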

Compound 4, half-maximal inhibitory concentration: 6590 nM
Estimate against measurement, compound 4: 1.5-fold (0.18 log units) above, within the range that was stated.
By their numbers in this assay, from the lowest: compounds 4, 1 and 3 (each within the scatter of the next); then compound 2.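

In this assay bromo ortho to a large group cannot be told from chloro at the same place (a 1.7-fold lower number from compound 3 to compound 4 (0.22 log units; within the scatter)). The 2-bromo-4-fluorophenyl compound also stays within the scatter of the 4-chlorophenyl compound (a 1.0-fold lower number from compound 1 to compound 4 (0.02 log units; within the scatter)) and remains clearly apart from the 4-(trifluoromethyl)phenyl compound (a 6.2-fold lower number from compound 2 to compound 4 (0.79 log units; beyond the scatter)). No measurement shown accounts for these steps. From the compounds shown here alone, whether an amine or a carboxylic acid at this place would keep the number in this range remains open. So does whether bromo and chloro would still match without the fluoro group.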